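This account rests on a few compounds, and the source may have more. Where it says the series, first, only, none or still open, it means among the compounds named here.

Working notes on the series, starting from compound 1 (`C/C=C/c1cccc(-c2cc3cn([C@H]4C[C@H](O)[C@@H](CO)O4)c(=O)nc3o2)c1`). In an ADME assay on HEL cells (Homo sapiens) for cytotoxicity (on this read-out higher numbers stand for lower toxicity in this test and lower numbers for higher toxicity in this test), compound 1 gives > 200000 nM, which is a limit of the assay and not a number. Compound 2 (`C/C=C/c1ccc(-c2cc3cn([C@H]4C[C@H](O)[C@@H](CO)O4)c(=O)nc3o2)cc1`) gives > 200000 nM, which is likewise a limit.

The next structure is compound 3 (`CCC/C=C/c1cccc(-c2cc3cn([C@H]4C[C@H](O)[C@@H](CO)O4)c(=O)nc3o2)c1`). It differs from compound 1 by ethyl in place of hydrogen on a saturated chain carbon bound to a double-bonded chain carbon, so that prop-1-en-1-yl becomes pent-1-en-1-yl.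

Among the measured compounds shown here, the only measured step is a step that the two limits leave unreadable from compound 1 to compound 2. It concerns a different change and gives no size to carry over to the chain extension. For the measured compounds named here, the series so far offers only (the limit of > 200000 nM in this assay, at which 2 of the 2 values shown sit), reached by compound 1 and compound 2 alike. On that basis, no step beyond the scatter is expected in this assay, and no direction can be argued, although a reading as a limit again is quite likely.

The expected change is an at least 1.1-fold lower number from compound 1 to compound 3 (0.04 log units; that floor lies within the scatter). Compound 3 is estimated at 180000 nM, with an expected range of 80000 nM to 300000 nM.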

Compound 3, half-maximal cytotoxic concentration: > 200000 nM
Compound 3 ended at the assay's limit; the forecaster's own chance of this, stated with the estimate: 65%; middle value at least 1.1-fold (0.04 log units) from the limit.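

In this assay compound 3 gives > 200000 nM, which is a limit and not a number. Its step from compound 1 therefore cannot be read, and no size can be given for the change from prop-1-en-1-yl to pent-1-en-1-yl. The compounds shown leave open whether that change moves the read-out at all, with compound 1, compound 2 and compound 3 all sitting at one value: the limit of > 200000 nM in this assay, at which 3 of the 3 values shown sit.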